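Replacing an Aromatic Ring with Oxan-4-yl

The compounds below may be only part of what the source reports. "The series", "measured", "known", "first", "only" and "open" are said of these compounds alone.

Compound 1 `COc1ccc(C(=O)N(Cc2ccncc2)Cc2cccc(OCCc3ccc(C)cc3)c2)cc1` gives 9100 nM in a functional assay on KMS-11 cells (Homo sapiens) for antiproliferative activity, read by CellTiter-Glo, with a stated time of 72 h (a lower number here means a stronger inhibitor, a higher number a weaker inhibitor), and compound 2 `COc1ccc(C(=O)N(Cc2ccncc2)Cc2cccc(OCCc3cccc(C(F)(F)F)c3)c2)cc1` gives 8900 nM in the same test, so compound 2 stands level with compound 1. Compound 3 `COc1ccc(C(=O)N(Cc2ccncc2)Cc2cccc(OCC3CCOCC3)c2)cc1` brings a larger change: oxan-4-yl in place of 3-(trifluoromethyl)benzyl on a saturated chain carbon bound to an oxygen on an aromatic ring. Among the measured compounds shown here, the only measured step is a 1.0-fold lower number from compound 1 to compound 2 (0.01 log units; within the scatter) and it merely exchanges 4-methylphenyl for 3-(trifluoromethyl)phenyl. For the measured compounds named here, no measured compound lacks that aromatic ring, so the guide is weak. The expected result is a 1.0-fold higher number from compound 2 to compound 3 (0.00 log units; within the scatter) and thus no shift beyond the scatter in this assay in either direction. Compound 3 is estimated at 9000 nM (range 3000 nM to 25000 nM) in this assay.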

Compound 3, half-maximal inhibitory concentration: 17700 nM
Estimate against measurement, compound 3: 2.0-fold (0.29 log units) below, within the range that was stated.
By their numbers in this assay, from the lowest: compounds 2, 1 and 3 (each within the scatter of the next).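

Swapping the aromatic ring for oxan-4-yl at this position gives a 2.0-fold higher number from compound 2 to compound 3 (0.30 log units; within the scatter) and a 1.9-fold higher number from compound 1 to compound 3 (0.29 log units; within the scatter) in this assay, so both steps stay within the scatter. The aromatic ring is therefore not shown to be needed here, even though the group shrinks from 11 heavy atoms to 6. Nothing measured on these compounds offers an explanation for this result.

On these data alone, whether an amine, a carboxylic acid or a longer chain at this oxygen would move the number beyond the scatter remains open.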